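Benzyl for Methyl on the Sulfur of Compound 3

The source may report more compounds than this note shows. Statements on the series, on what has been measured and on what is new or still open speak of the compounds shown alone.

Compound 3 `CSc1nc(N)nc2c1ncn2/C=C1/CC1(CO)CO` is examined in an ADME assay on MOLT-3 cells (Homo sapiens) for cytotoxicity, with a stated time of 7 days; on this read-out higher numbers stand for lower toxicity in this test and lower numbers for higher toxicity in this test. In this assay compound 3 gives > 20000 nM, which is a limit of the assay and not a number. Compound 1 `Nc1nc(OCc2ccccc2)c2ncn(/C=C3/CC3(CO)CO)c2n1` also reaches only the limit > 20000 nM in this assay. Compound 2 `CCCCCCCCSc1nc(N)nc2c1ncn2/C=C1/CC1(CO)CO` likewise shows only the limit > 20000 nM in this assay. Hence (the limit of > 20000 nM in this assay, at which 3 of the 3 values shown sit), and the steps a step that the two limits leave unreadable from compound 1 to compound 3, a step that the two limits leave unreadable from compound 1 to compound 2 and a step that the two limits leave unreadable from compound 2 to compound 3 remain unreadable in size. Compound 4 `Nc1nc(SCc2ccccc2)c2ncn(/C=C3/CC3(CO)CO)c2n1` differs from compound 3 by phenyl in place of hydrogen on a saturated chain carbon bound to a sulfur. With every comparison ending at the limit, no step size can be derived, so compound 4 is expected to stay at the limit as well. Compound 4 is estimated at 25000 nM, within 12000 nM to 60000 nM. The expected step is therefore a step that the limit leaves unreadable from compound 3 to compound 4, none beyond the scatter.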

Compound 4, half-maximal cytotoxic concentration: > 20000 nM
Compound 4 ended at the assay's limit (the forecaster's own chance of this, stated with the estimate: 85%); the middle value does not contradict the limit.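

In this assay compound 4 sits at the same limit as compound 1, compound 2 and compound 3, so no step among these compounds can be read: the limit of > 20000 nM in this assay, at which 4 of the 4 values shown sit. The compounds shown leave open how far apart their cytotoxic concentrations lie, and whether any of the sulfur or oxygen groups changes them at all.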